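From a Chlorinated Aryl Group to a Methylated Imine

The source may hold more compounds than are shown below. What is called first, only, known or untested is meant among the compounds shown, and "the series" means these compounds.

Compound 1 `CC1=CC[C@@H]([C@@](C)(O)CCCC(C)(C)NC(=S)N/N=C\c2ccc(O)cc2)CC1` gives 20700 nM in a functional assay on NCI-H460 cells (Homo sapiens) for cytotoxicity, read by sulforhodamine B assay; a lower number here means a stronger inhibitor of growth, a higher number a weaker inhibitor of growth.
Compound 2 `CC1=CC[C@@H]([C@@](C)(O)CCCC(C)(C)NC(=S)N/N=C\c2cccc(Cl)c2)CC1` gives only > 100000 nM in this assay, a limit of the assay rather than a number.

Compound 2 therefore stands at the limit (the limit of > 100000 nM in this assay, at which 1 of the 2 values shown sits), so no number is known for it. Compound 3 `CC1=CC[C@@H]([C@@](C)(O)CCCC(C)(C)NC(=S)N/N=C(/C)c2ccccc2)CC1` differs from it by a group of 9 heavy atoms (8 carbon, 1 nitrogen; one six-membered aromatic ring of carbon only) in place of a group of 9 heavy atoms (7 carbon, 1 nitrogen, 1 chlorine; one six-membered aromatic ring of carbon only), on an amide-type nitrogen. For the measured compounds named here, only one measured step touches this position: an at least 4.8-fold higher number from compound 1 to compound 2 (0.68 log units; beyond the scatter), which moved the number up to the limit. Since compound 2 itself has no number, the step from compound 2 to compound 3 cannot be sized from the data; it can only be judged against compound 1. Compound 3 carries neither the hydroxyl of compound 1 nor the chlorine of compound 2, and is expected to sit between them, at an estimated 60000 nM with a range from 20000 nM to 200000 nM. The expected step is an at least 1.6-fold lower number from compound 2 to compound 3 (0.22 log units; that floor lies within the scatter).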

Compound 3, concentration for total growth inhibition: > 100000 nM
Compound 3 gave a limit, no number; the forecaster's own chance of this, stated with the estimate: 45%; at least 1.6-fold (0.22 log units) between middle value and limit.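

Compound 3 carries no chlorine, yet in this assay it also gives no number, so the chlorine of compound 2 is not needed for this loss of growth inhibition. Against the 4-hydroxyphenyl group of compound 1, the group on the amide-type nitrogen in compound 3 gives an at least 4.8-fold higher number from compound 1 to compound 3 (0.68 log units; beyond the scatter). Among the compounds shown, only compound 1 gives a measured number, and the size of any difference between the other two cannot be read: the limit of > 100000 nM in this assay, at which 2 of the 3 values shown sit.

Compound 3 both lacks the hydroxyl and carries an extra methyl on the carbon with a double bond to nitrogen, so these compounds do not show how much each change contributes. From the compounds shown here alone, it also remains open whether an amine in place of the hydroxyl would give a measurable number in this assay.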